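A Methoxy Addition on the Side Chain of Compound 2

The compounds below may be only part of what the source reports. "The series", "measured", "known", "first", "only" and "open" are said of these compounds alone.

Two compounds share a core and differ in the aryl group on the amine. Compound 1, `Cc1nc(Nc2c(C)cc(Cl)cc2Cl)c(=O)n(C(C)C2CC2)n1`, carries a methyl and a chlorine on that ring together with a second chlorine; in an assay on isolated protein for displacement of a labelled ligand from corticotropin-releasing factor receptor 1 (Rattus norvegicus) (on this read-out higher numbers stand for weaker inhibition and lower numbers for stronger inhibition), compound 1 gives 33 nM. Compound 2, `Cc1nc(Nc2c(Cl)cc(C(F)(F)F)cc2Cl)c(=O)n(C(C)C2CC2)n1`, carries a trifluoromethyl flanked by two chlorines, and in this assay compound 2 gives 14 nM, the lowest of the two numbers; compound 1 stands a distance beyond the scatter above it.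

Compound 3, `COCC(C1CC1)n1nc(C)nc(Nc2c(Cl)cc(C(F)(F)F)cc2Cl)c1=O`, keeps the aryl group of compound 2 and changes only the side chain: methoxy in place of hydrogen on a saturated chain carbon, two bonds along the chain from an aromatic nitrogen and a saturated ring carbon. Among the compounds with values here, no measured pair shows this change, so its effect is unknown. Since the pair from compound 1 to compound 2 concerns a different part of the molecule, nothing there bears on it.

The step of a 1.2-fold lower number from compound 2 to compound 3 (0.07 log units; within the scatter) is expected to stay within the scatter, with no direction favoured. Compound 3 is therefore estimated at 12 nM, within a range from 4 nM to 40 nM.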

Compound 3, half-maximal inhibitory concentration: 11 nM
For compound 3 the middle estimate is 1.1-fold (0.04 log units) above the measured one, within the range that was stated.
By their numbers in this assay, from the lowest: compounds 3 and 2 (each within the scatter of the next); then compound 1.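

In this assay, the methoxy addition gives a 1.3-fold lower number from compound 2 to compound 3 (0.10 log units; within the scatter), so this pair offers no basis for ranking compound 2 and compound 3. Within the data shown here, it is the first measured pair that changes the side chain rather than the aryl group, and it shows that, with the aryl group of compound 2 in place, going from 1-cyclopropylethyl to 1-cyclopropyl-2-methoxyethyl leaves the number in this assay indistinguishable from that of the parent. No accompanying information on the compounds accounts for this outcome, so the result stands as an observation on binding numbers alone.

This single pair leaves open whether the same methoxy addition would behave alike on the aryl group of compound 1, where a methyl stands in place of one chlorine and a chlorine in place of the trifluoromethyl. It also leaves open how this saturated chain carbon would respond to other groups in place of hydrogen, such as a hydroxyl, an amine, a carboxylic acid or a longer ethoxy chain, any of which could move the number beyond the scatter or leave it there.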